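Trimming One Methyl from the Aryl Ring

The source may report more compounds than this note shows. Statements on the series, on what has been measured and on what is new or still open speak of the compounds shown alone.

Of the compounds shown here, three sharing one core have been measured in an assay on CHO cells for displacement of a labelled ligand from corticotropin-releasing factor receptor 1 (Homo sapiens); on this read-out higher numbers stand for weaker inhibition and lower numbers for stronger inhibition. Compound 1 `CCN(CC)c1nc2c(c(-c3c(C)cc(C)cc3C)cn2C)c(=O)n1C` gives 7700 nM. Compound 2 `CCCN(CCC)c1nc2c(c(-c3c(C)cc(C)cc3C)cn2C)c(=O)n1C` gives 120 nM in this assay, and the change is a 64-fold lower number from compound 1 to compound 2 (1.81 log units; beyond the scatter). Compound 3 `CCCN(CCC)c1nc2c(c(-c3c(C)cc(C)cc3C)c(C)n2C)c(=O)n1C` gives 1100 nM in this assay, so that a 9.2-fold higher number from compound 2 to compound 3 (0.96 log units; beyond the scatter). Among the three numbers compound 3 stands second highest: a stronger inhibitor than compound 1, a weaker one than compound 2.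

Compound 4 `CCCN(CCC)c1nc2c(c(-c3ccc(C)cc3C)c(C)n2C)c(=O)n1C` differs from compound 3 in one place: hydrogen in place of methyl on an aromatic carbon, on an aromatic carbon of a six-membered aromatic ring of carbon only, ortho to a large group and meta to two methyl groups; read one bond further out, 2,4,6-trimethylphenyl becomes 2,4-dimethylphenyl. Neither measured step touches this ring. The step from compound 1 to compound 2 changed the amino group, and the step from compound 2 to compound 3 added a methyl on the core, with a modest effect. Among the compounds with values here, no measured step therefore speaks directly to this change. The expected step is accordingly a 2.3-fold higher number from compound 3 to compound 4 (0.36 log units; beyond the scatter), a small weakening at most, and it is an estimate only. The expected value for compound 4 in this assay is 2500 nM, within a range from 700 nM to 9000 nM.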

Compound 4, half-maximal inhibitory concentration: 3300 nM
Compound 4: the middle estimate sits 1.3-fold (0.12 log units) below what was measured; the range from low to high includes it.
By their numbers in this assay, from the lowest: compound 2; then compound 3; then compound 4; then compound 1.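

Within the data shown here, this is the first direct reading on the aryl ring: in this assay, swapping one methyl for hydrogen turns 2,4,6-trimethylphenyl into 2,4-dimethylphenyl and gives a 3.0-fold higher number from compound 3 to compound 4 (0.48 log units; beyond the scatter), which means weaker inhibition, so the methyl that leaves does count towards the inhibition seen with compound 3. The earlier steps shown here spoke only of other places, and this modest change on the ring is much smaller than the change of the amino group, a 64-fold lower number from compound 1 to compound 2 (1.81 log units; beyond the scatter), though it remains beyond the usual scatter of the measurement. What lies behind the loss cannot be said, since no separate measurement here bears on why removing this methyl weakens inhibition.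

From the compounds shown here alone, the change has been read only on the core of compound 3, which carries the extra core methyl, so whether it would cost the same on the core of compound 2 stays open. Also open, going by these compounds, is how a chlorine atom or a methoxy group would behave on that same ring carbon, and so whether the methyl itself matters or any group larger than hydrogen would serve there.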